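Removing a Fluorine and the Solubility Expected

The compounds below may be only part of what the source reports. "The series", "measured", "known", "first", "only" and "open" are said of these compounds alone.

Compound 1 `CN(C)C(=O)CCNC(=O)c1cc(-c2ccc(F)cc2)no1` and compound 2 `CC(=O)N1CC2(CC(NC(=O)c3cc(-c4ccc(F)cc4)no3)C2)C1` share a core and were both tested in a physicochemical assay for solubility, at pH 6.8; a higher number here means a more soluble compound, a lower number a less soluble compound. For compound 1 the result is an assay limit rather than a number, > 100 ug/mL. For compound 2 the result is likewise an assay limit, > 100 ug/mL. Compound 2 thus stands at the limit of > 100 ug/mL in this assay, at which 2 of the 2 values shown sit, with no numeric value available. Compound 3 `CC(=O)N1CC2(CC(NC(=O)c3cc(-c4ccccc4)no3)C2)C1` differs from compound 2 by hydrogen in place of fluoro on an aromatic carbon. Among the compounds with values here, no measured step covers such a change, and the step that the limit leaves unreadable from compound 2 to compound 3 is expected to stay within the usual scatter, in no clear direction. In this assay compound 3 is estimated at 150 ug/mL, within 80 ug/mL to 300 ug/mL, likely again reported as a limit.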

Compound 3, solubility: > 100 ug/mL
Compound 3 ended at the assay's limit; the forecaster's own chance of this, stated with the estimate: 80%; the middle value does not contradict the limit.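

No step can be read from compound 2 to compound 3, since both results are assay limits rather than numbers: the limit of > 100 ug/mL in this assay, at which 3 of the 3 values shown sit. The compounds shown leave open how soluble each one actually is, and whether going from 4-fluorophenyl to phenyl changes that at all.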